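The compounds below may be only part of what the source reports. "The series", "measured", "known", "first", "only" and "open" are said of these compounds alone.

In a functional assay on MDA-MB-436 cells (Homo sapiens) for antiproliferative activity, read by MTT assay, with a stated time of 24 h (on this read-out lower numbers stand for stronger inhibition and higher numbers for weaker inhibition), compound 1 (`O=C(O)CC(NS(=O)(=O)c1ccccc1)c1ccccc1`) gives > 100000 nM, which is a limit of the assay and not a number. Compound 2 (`O=C(O)CC(NS(=O)(=O)c1cccc([N+](=O)[O-])c1)c1ccccc1`) also gives only a limit, > 100000 nM. Compound 3 (`O=C(O)CC(NC(=O)c1ccc(Cl)cc1Cl)c1ccccc1F`) likewise gives only a limit, > 100000 nM. Compound 4 (`O=C(O)CC(NS(=O)(=O)c1cccc([N+](=O)[O-])c1)c1ccc(Cl)cc1Cl`) carries 2,4-dichlorophenyl in place of phenyl on a saturated chain carbon bound to a saturated chain carbon and a sulfonamide nitrogen. For the measured compounds named here, the only measured step, a step that the two limits leave unreadable from compound 1 to compound 2, is a different change and gives no size to carry over, while (the limit of > 100000 nM in this assay, at which 3 of the 3 values shown sit). No step beyond the scatter and no direction is therefore expected in this assay, and the expected a number no higher from compound 2 to compound 4 (the limit leaves the size open) rests on that. For compound 4 the estimate is 100000 nM, with an expected range of 40000 nM to 200000 nM.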

Compound 4, half-maximal inhibitory concentration: > 100000 nM
Compound 4: a limit, no number (the forecaster's own chance of this, stated with the estimate: 75%); the middle value lies on the limit itself.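

The step from compound 2 to compound 4 cannot be read, since both results are limits and not numbers: the limit of > 100000 nM in this assay, at which 4 of the 4 values shown sit.

The compounds shown leave open which change to the shared core, if any, would give a measurable number in this assay.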